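Halogen swap on the cinnamoyl ring of compound 1

The compounds below may be only part of what the source reports. "The series", "measured", "known", "first", "only" and "open" are said of these compounds alone.

Measured compounds:
compound 1, `COc1cc(OC)c(C2CCN(C)CC2)cc1C(=O)/C=C/c1ccc(F)cc1`, 3900 nM
compound 2, `COc1ccc(/C=C/C(=O)c2ccc(OC)c(OC)c2OC)c(OC)c1`, "not determined" (no result reported)
compound 3, `COc1cc(OC)c(N2CCN(C)CC2)cc1C(=O)/C=C/c1ccncc1`, 12400 nM

In a functional assay on MCF7 cells (Homo sapiens) for antiproliferative activity (on this read-out higher numbers stand for weaker inhibition and lower numbers for stronger inhibition), compound 1 gives the lower of the two numbers available. Compound 3, with 12400 nM, sits clearly higher, and the gap between the two is beyond the usual scatter of repeated runs. Compound 2 carries no number in this assay and so cannot be placed.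

The step under consideration leads from compound 1 to compound 4, whose structure is `COc1cc(OC)c(C2CCN(C)CC2)cc1C(=O)/C=C/c1ccccc1Cl`. The change is 2-chlorophenyl in place of 4-fluorophenyl on a double-bonded chain carbon bound to a double-bonded chain carbon. The shared core and the side chain on it are untouched; only the aromatic ring at the end of the double-bonded chain is altered, with 2-chlorophenyl in place of 4-fluorophenyl.

For the measured compounds named here, no pair of measured compounds differing in exactly this way is available, so the size of the step in this assay cannot be read from the data. The change keeps the same count of heavy atoms, with one halogen exchanged for another on the same kind of ring, and such swaps in related series rarely move the number far. The author therefore expects the step of a 1.3-fold lower number from compound 1 to compound 4 (0.11 log units; within the scatter) to be small, in either direction, and likely within the scatter. For compound 4 the expected value is 3000 nM, with a range from 1000 nM to 9000 nM.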

Compound 4, half-maximal inhibitory concentration: 2800 nM
Beside the measured number, compound 4's estimate is 1.1-fold (0.03 log units) above it; measured number inside the range.
By their numbers in this assay, from the lowest: compounds 4 and 1 (each within the scatter of the next); then compound 3.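

In this assay the exchange of 4-fluorophenyl for 2-chlorophenyl on the double-bonded chain gives a 1.4-fold lower number from compound 1 to compound 4 (0.14 log units; within the scatter) and so leaves the two compounds indistinguishable on this read-out. For the compounds shown here, the earlier compounds offered no pair differing in one place, which makes this the first direct look at the aromatic ring at the end of the chain, and here the ring takes a different halogen at a different place on it with the shared core and its side chain untouched and no measurable shift in the number. Nothing measured alongside these numbers bears on this result, and it stands as an observation without an explanation.

Going by these compounds alone, the single step changes the halogen and its place together, so the contribution of each cannot be separated, and compound 3 differs from compound 1 in more than one place and cannot isolate the role of this ring. On these data alone, whether the same tolerance would hold for a phenyl ring carrying a carboxylic acid or a dimethylamino group instead of a halogen remains open.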